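Dropping the isopropyl group from compound 1

The compounds below may be only part of what the source reports. "The series", "measured", "known", "first", "only" and "open" are said of these compounds alone.

Compound 1, `CCCc1nc(C)c2c(C(C)C)nnc(S)n12`, shows only a limit in a functional assay for inhibition, with Homo sapiens as the target (on this read-out higher numbers stand for weaker inhibition and lower numbers for stronger inhibition), reported as > 48000 nM. Compound 2, `CCCc1nc(C)c2c(C(C)C)nnc(SC)n12`, likewise shows only a limit in this assay, reported as > 48000 nM. Going by the values given here, the single measured step, a step that the two limits leave unreadable from compound 1 to compound 2, is methyl in place of hydrogen on a sulfur, and its size cannot be read because both of its values sit at the limit of > 48000 nM in this assay, at which 2 of the 2 values shown sit. Compound 3, `CCCc1nc(C)c2cnnc(S)n12`, differs from compound 1 by hydrogen in place of isopropyl on an aromatic carbon. Among the compounds with values here, no measured step touches this position, so the only guide is that every value seen so far rests at the same limit, with nothing to suggest that compound 1 inhibits at all within the tested range. For compound 3 the expected step is therefore a step that the limit leaves unreadable from compound 1 to compound 3, small and of no clear direction. Compound 3 is estimated at 60000 nM, within a range from 20000 nM to 200000 nM, most likely again as a limit.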

Compound 3, half-maximal inhibitory concentration: 10000 nM
Estimate against measurement, compound 3: 6.0-fold (0.78 log units) above; the whole stated range lies above it.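

In this assay, hydrogen in place of isopropyl on this aromatic carbon gives an at least 4.8-fold lower number from compound 1 to compound 3 (0.68 log units; beyond the scatter), and a lower number here means stronger inhibition. Compound 3 is thus the first compound shown with a measured number rather than a limit, so this position, para to a sulfanyl group, does affect the read-out, and the step could be larger than the part that can be read. Compound 1 and compound 2 remain at one shared limit, which leaves the step on the sulfur unreadable: the limit of > 48000 nM in this assay, at which 2 of the 3 values shown sit.

Only isopropyl and hydrogen are shown at this carbon, so how a methyl, a cyclopropyl or an amine would read there stays open. Also open, on these data alone, is how a methyl on the sulfur would read on compound 3.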